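Replacing 3-ethylphenyl with 4-bromophenyl in the series

The source may hold more compounds than are shown below. What is called first, only, known or untested is meant among the compounds shown, and "the series" means these compounds.

Values so far in a functional assay on HT-29 cells (Homo sapiens) for antiproliferative activity, read by sulforhodamine B assay, with a stated time of 48 h; on this read-out lower numbers stand for stronger inhibition and higher numbers for weaker inhibition
- compound 1 `CCCCc1ccc(NS(=O)(=O)c2ccc(N3CCNC3=O)cc2)cc1` gives 610 nM
- compound 2 `O=C1NCCN1c1ccc(S(=O)(=O)Nc2ccc(I)cc2)cc1` gives 650 nM
- compound 3 `CCc1cccc(NS(=O)(=O)c2ccc(N3CCNC3=O)cc2)c1` gives 110 nM

Compound 3 (110 nM) holds the lowest number of the three, and both other compounds stand clearly higher, compound 1 at 610 nM and compound 2 at 650 nM in this assay on the same scale.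

Next comes compound 4 `O=C1NCCN1c1ccc(S(=O)(=O)Nc2ccc(Br)cc2)cc1`, with 4-bromophenyl in place of 3-ethylphenyl on a sulfonamide nitrogen.

Among the compounds with values here, two measured steps bear on this. Placing 3-ethylphenyl where 4-iodophenyl stood gave a 5.9-fold lower number from compound 2 to compound 3 (0.77 log units; beyond the scatter) and is the closest precedent, since the change now in view runs the opposite way with a different halogen. Iodo in place of butyl gave a 1.1-fold higher number from compound 1 to compound 2 (0.03 log units; within the scatter) and so shows no separation between those two groups. Within the data shown here, no bromo compound has been measured, so the comparison with iodo remains untested.

The estimate therefore leans on compound 2 (650 nM) as the nearest reference. Expected in this assay is a 5.5-fold higher number from compound 3 to compound 4 (0.74 log units; beyond the scatter) as a rise of similar size to the measured one, reversed.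

Compound 4 is estimated at 600 nM (expected range 250 nM to 1300 nM).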

Compound 4, half-maximal inhibitory concentration: 300 nM
Compound 4: middle estimate off by 2.0-fold (0.30 log units), on the high side; low and high end bracket the measured number.
By their numbers in this assay, from the lowest: compound 3; then compound 4; then compounds 1 and 2 (each within the scatter of the next).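

In this assay, the group on this aromatic carbon now makes a difference among halogen and alkyl: bromo in place of iodo gives a 2.2-fold lower number from compound 2 to compound 4 (0.34 log units; beyond the scatter) and bromo in place of butyl gives a 2.0-fold lower number from compound 1 to compound 4 (0.31 log units; beyond the scatter), although iodo and butyl themselves could not be told apart. Among the sulfonamide nitrogen groups, 3-ethylphenyl keeps the lowest number of the four compounds, with a 2.7-fold higher number from compound 3 to compound 4 (0.44 log units; beyond the scatter) on moving to 4-bromophenyl, so this halogen recovers only part of the distance between 4-iodophenyl and 3-ethylphenyl. No supporting measurement is available to explain any of these steps.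

The compounds shown do not separate the identity of the ethyl group from where it sits on the phenyl ring, so the low number of compound 3 cannot yet be assigned to either. As far as these compounds go, how a smaller halogen such as chloro or fluoro, an amine or a carboxylic acid on this phenyl ring would read also stays open, as does whether the order seen here extends beyond these four compounds.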